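This account rests on a few compounds, and the source may have more. Where it says the series, first, only, none or still open, it means among the compounds named here.

Compound 1 `Cc1cc(C(=O)O)ccc1CN1CCC[C@H](OC(c2cc(Cl)cc(Cl)c2)C(C)O)[C@@H]1c1ccccc1` gives 5300 nM in an assay on isolated protein for activation of cGMP-dependent protein kinase 1 (Homo sapiens), read by ADP-Glo, with stated times of 30 min and 2 h, in the presence of a further agent that is not named here (on this read-out higher numbers stand for an effect only at larger amounts of compound and lower numbers for an effect already at smaller amounts), and stands second highest of the three numbers in hand. Compound 3 `COC(=O)Nc1cc(C(=O)O)ccc1CN1CCC[C@H](O[C@H](CO)c2cc(Cl)cc(Cl)c2)[C@@H]1c1ccccc1` gives 1000 nM in this assay, the lowest of the three, while compound 2 `Cc1cc(C(=O)O)ccc1CN1CCC[C@H](OC(c2cc(Cl)cc(Cl)c2)C(C)(C)O)[C@@H]1c1ccccc1` gives 17000 nM in this assay, the highest. For the measured compounds named here, the only single-point step available is a 3.2-fold higher number from compound 1 to compound 2 (0.51 log units; beyond the scatter), which concerns the saturated chain and not the aromatic ring.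

The change from compound 1 to compound 4 `Cc1cc(C(=O)O)ccc1CN1CCC[C@H](O[C@H](CO)c2ccccc2)[C@@H]1c1ccccc1` is a group of 9 heavy atoms (8 carbon, 1 oxygen; one six-membered aromatic ring of carbon only) in place of a group of 12 heavy atoms (9 carbon, 1 oxygen, 2 chlorine; one six-membered aromatic ring of carbon only), on an oxygen on a saturated carbon. Going by the values given here, no measured step covers this change. Compound 3 carries the same kind of chain as enters in compound 4 while keeping both chlorines, but it also differs from compound 1 at the core, so its number cannot be read as a step. The expectation rests on compound 1 alone, and a step toward higher numbers, well beyond the scatter, is expected for a 3.8-fold higher number from compound 1 to compound 4 (0.58 log units; beyond the scatter), with wide uncertainty. Compound 4 is therefore estimated at 20000 nM in this assay, within a range from 5000 nM to 80000 nM.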

Compound 4, half-maximal effective concentration: 25000 nM
Estimate against measurement, compound 4: 1.3-fold (0.10 log units) below; the measured number falls inside the stated range.
By their numbers in this assay, from the lowest: compound 3; then compound 1; then compounds 2 and 4 (each within the scatter of the next).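

In this assay, for the compounds shown here, a 4.7-fold higher number from compound 1 to compound 4 (0.67 log units; beyond the scatter) is the first step at this position that involves the aromatic ring, as the earlier step touched only the saturated chain. The step shows that the group on the oxygen on a saturated carbon affects the number, and that the chlorine-free 2-hydroxy-1-phenylethyl group goes with a higher number, but it changes the chlorines and the chain together, so it cannot be assigned to either alone. No measurement at hand explains the step.

From the compounds shown here alone, how much of the step belongs to the chlorines and how much to the chain remains open, as does the part played by the defined stereocentre of the entering group. Also open, going by these compounds, is how this assay would read a fluorine on the aromatic ring, or an amine in place of the chain hydroxyl.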